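The source may report more compounds than this note shows. Statements on the series, on what has been measured and on what is new or still open speak of the compounds shown alone.

Notes on the series. Compound 1 `CCCS(=O)(=O)Nc1ccc(F)c(C(=O)c2n[nH]c3ncc(-c4ccc(N)cc4)cc23)c1F`, compound 2 `CCCS(=O)(=O)Nc1ccc(F)c(C(=O)c2n[nH]c3ncc(-c4ccc(OC)cc4Cl)cc23)c1F` and compound 3 `CCCS(=O)(=O)Nc1ccc(F)c(C(=O)c2n[nH]c3ncc(-c4ccc(S(=O)(=O)NC)cc4)cc23)c1F` share one core and differ only in the group carried on the six-membered aromatic ring of carbon only. In an assay for binding affinity to dual specificity mitogen-activated protein kinase kinase 4 (Homo sapiens), read by KINOMEscan, tested at 100 nM (a higher number here means a weaker effect of the compound at the concentration tested, a lower number a stronger effect), compound 1 gives 0.1%, compound 2 gives 5.3% and compound 3 gives 1.2%. The three numbers sit close together: a number 1.1 percentage points higher from compound 1 to compound 3 (within the scatter), and a number 4.1 percentage points lower from compound 2 to compound 3 (within the scatter). Compound 3 thus stands among the other two with no gap beyond the scatter to either.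

Compound 4 `CCCS(=O)(=O)Nc1ccc(F)c(C(=O)c2n[nH]c3ncc(-c4ccc(C(=O)O)cc4)cc23)c1F` is not yet measured. Relative to compound 3 the change is carboxy in place of methylsulfamoyl on an aromatic carbon. Among the compounds with values here, two measured steps bear on it, both at the same place on that ring: the exchange of amino for methylsulfamoyl from compound 1 to compound 3, and the exchange of the whole aryl group from compound 2 to compound 3; neither moved the number beyond the scatter. A step of about a number 0.3 percentage points higher from compound 3 to compound 4 (within the scatter) in this assay is therefore expected, none beyond the scatter. Compound 4 is expected to give 1.5% in this assay, within a range from 0.1% to 8%.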

Compound 4, a percentage reported as activity, at one concentration (the size of the read-out at that concentration, not a potency): 0.1%
For compound 4 the middle estimate is 1.4 percentage points above the measured one; the measured number falls inside the stated range.
By their numbers in this assay, from the lowest: compounds 1, 4, 3 and 2 (each within the scatter of the next).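

In this assay, carboxy in place of methylsulfamoyl gives a number 1.1 percentage points lower from compound 3 to compound 4 (within the scatter), 4-carboxyphenyl in place of 2-chloro-4-methoxyphenyl gives a number 5.2 percentage points lower from compound 2 to compound 4 (within the scatter), and carboxy in place of amino gives no change at the digits printed from compound 1 to compound 4 (within the scatter). Within the data shown here, the place para to a large group thus now holds carboxy as well as amino and methylsulfamoyl, and no step among the four compounds lies beyond the scatter, so this change adds a fourth group without separating any pair. No measurement at hand accounts for this result.

A read-out at one concentration leaves open whether these compounds differ in potency. Also open, on these data alone, is whether a longer chain ending in a carboxylic acid, a primary carboxamide or a tertiary amine at the same place would stay within the scatter of compound 4.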